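Swapping propyl for but-1-yn-1-yl: notes on cytotoxicity

The compounds below may be only part of what the source reports. "The series", "measured", "known", "first", "only" and "open" are said of these compounds alone.

Measured in an ADME assay on L1210/0 cells (Mus musculus) for cytotoxicity, with a stated time of 48 h; on this read-out higher numbers stand for weaker inhibition and lower numbers for stronger inhibition:
- compound 1 `C=C(Cl)c1cn([C@H]2C[C@H](O)[C@@H](CO)O2)c(=O)[nH]c1=O`: 1660 nM
- compound 2 `CCCc1cn([C@H]2C[C@H](O)[C@@H](CO)O2)c(=O)[nH]c1=O`: > 200000 nM (a limit)

Compound 2 has no exact number, only the limit > 200000 nM.

Compound 3 `CCC#Cc1cn([C@H]2C[C@H](O)[C@@H](CO)O2)c(=O)[nH]c1=O` carries but-1-yn-1-yl in place of propyl on an aromatic carbon.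

Going by the values given here, the one measured step at this position is large: an at least 120-fold higher number from compound 1 to compound 2 (2.08 log units; beyond the scatter). It went with propyl in place of 1-chloroethenyl. On that single step, a moderate to large move to a lower number is expected in this assay, though a result at the limit remains possible.

The expected step is an at least 6.6-fold lower number from compound 2 to compound 3 (0.82 log units; beyond the scatter).

For compound 3 the estimate is 30000 nM, with an expected range of 4000 nM to 200000 nM.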

Compound 3, half-maximal inhibitory concentration: > 200000 nM
Compound 3: only a limit was reported; the forecaster's own chance of this, stated with the estimate: 25%; at least 6.6-fold (0.82 log units) between middle value and limit.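

In this assay, but-1-yn-1-yl at this aromatic carbon does not keep what 1-chloroethenyl gives, with an at least 120-fold higher number from compound 1 to compound 3 (2.08 log units; beyond the scatter). For compound 3, > 200000 nM is a limit and not a number. The step between compound 2 and compound 3 cannot be read, since both stand at the same limit: the limit of > 200000 nM in this assay, at which 2 of the 3 values shown sit.

Open, from the compounds shown here alone, is whether plain ethenyl or 1-bromoethenyl at this carbon would give a number rather than a limit. Going by these compounds, how far compound 2 and compound 3 lie past the limit also stays unknown.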